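Shifting the Chlorine on the Hydrazone Aryl Ring

The source may report more compounds than this note shows. Statements on the series, on what has been measured and on what is new or still open speak of the compounds shown alone.

Measured compounds in a functional assay on MCF7 cells (Homo sapiens) for antiproliferative activity, read by MTT assay, with a stated time of 72 h; on this read-out higher numbers stand for weaker inhibition and lower numbers for stronger inhibition:
Compound 1, `CCCSc1nc(N/N=C(\C)c2ccccc2O)c2nnn(Cc3ccccc3Cl)c2n1`, gives > 64000 nM, which is a limit of the assay and not a number.
Compound 2, `CCCSc1nc(N/N=C/c2ccc(Cl)cc2)c2nnn(Cc3ccccc3)c2n1`, gives > 64000 nM, again a limit of the assay.
Compound 3, `C#CCSc1nc(N/N=C(\C)c2ccccc2O)c2nnn(Cc3ccccc3)c2n1`, gives 11300 nM.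

Among the three values shown, compound 2 stands at the limit of the assay, and it shares that position with compound 1; (the limit of > 64000 nM in this assay, at which 2 of the 3 values shown sit). Only compound 3 returns a number.

The compound still to be tested is compound 4, `CCCSc1nc(N/N=C/c2cccc(Cl)c2)c2nnn(Cc3ccccc3)c2n1`. It differs from compound 2 only in one place: 3-chlorophenyl in place of 4-chlorophenyl on a carbon with a double bond to nitrogen.

Going by the values given here, no step between measured compounds is available here, so the size of the move from compound 2 to compound 4 cannot be read from a measured pair. Since compound 2 sits at the limit, any expected step toward weaker inhibition cannot be resolved, and a step toward stronger inhibition would have to be large to register as a number. The step from compound 2 to compound 4 is expected to be a step that the limit leaves unreadable from compound 2 to compound 4, essentially no change beyond the scatter. Compound 4 is therefore expected to give about 70000 nM, within the range 30000 nM to 200000 nM, most likely reported again as a limit.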

Compound 4, half-maximal inhibitory concentration: > 64000 nM
Compound 4 gave a limit, no number; the forecaster's own chance of this, stated with the estimate: 70%; the middle value lies beyond the limit too.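

In this assay compound 4 gives > 64000 nM, which is a limit of the assay and not a number. Compound 2 stands at a limit as well, so no step can be read between compound 2 and compound 4: the limit of > 64000 nM in this assay, at which 3 of the 4 values shown sit.

The compounds shown leave open whether 3-chlorophenyl and 4-chlorophenyl differ in antiproliferative activity at all.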